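Changing the Group on the Nitrogen of Compound 3

The compounds below may be only part of what the source reports. "The series", "measured", "known", "first", "only" and "open" are said of these compounds alone.

In a functional assay on K562 cells (Homo sapiens) for cytotoxicity, read by trypan blue exclusion, with a stated time of 96 h (a higher number here means a weaker inhibitor, a lower number a stronger inhibitor), compound 1 (`COc1cc(OC)c(/C=C/S(=O)(=O)Cc2ccc(OC)c([N+](=O)[O-])c2)c(OC)c1`) gives 2500 nM. Compound 2 (`COC(=O)CCNc1cc(CS(=O)(=O)/C=C/c2c(OC)cc(OC)cc2OC)ccc1OC`) gives 1000 nM, and compound 3 (`COC(=O)C(Nc1cc(CS(=O)(=O)/C=C/c2c(OC)cc(OC)cc2OC)ccc1OC)c1ccc(Br)cc1`) gives 200 nM, the lowest number of the three. Two measured steps lead there. The first is a 2.5-fold lower number from compound 1 to compound 2 (0.40 log units; beyond the scatter), where (2-(methoxycarbonyl)ethyl)amino replaces nitro. The second is a 5.0-fold lower number from compound 2 to compound 3 (0.70 log units; beyond the scatter), where (4-bromophenyl)(methoxycarbonyl)methyl replaces 2-(methoxycarbonyl)ethyl on a nitrogen on an aromatic ring.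

Compound 4 (`COc1cc(OC)c(/C=C/S(=O)(=O)Cc2ccc(OC)c(NC(F)(F)C(=O)O)c2)c(OC)c1`) is changed at that same place: carboxy(difluoro)methyl in place of (4-bromophenyl)(methoxycarbonyl)methyl on a nitrogen on an aromatic ring. Here carboxy(difluoro)methyl takes the place of (4-bromophenyl)(methoxycarbonyl)methyl. The second step bears most directly on this change, and it was modest. Like the 2-(methoxycarbonyl)ethyl of compound 2, the entering group has no ring, so part of the gain seen in a 5.0-fold lower number from compound 2 to compound 3 (0.70 log units; beyond the scatter) may be lost. Yet no measured compound carries carboxy(difluoro)methyl, which makes this only a rough guide.

In this assay, no step beyond the scatter is expected, with a slight drift toward a higher number. The expected result is a 1.5-fold higher number from compound 3 to compound 4 (0.18 log units; within the scatter). The estimate for compound 4 is 300 nM, with an expected range from 50 nM to 1500 nM.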

Compound 4, half-maximal inhibitory concentration: 150 nM
Compound 4: middle estimate off by 2.0-fold (0.30 log units), on the high side, within the range that was stated.
By their numbers in this assay, from the lowest: compounds 4 and 3 (each within the scatter of the next); then compound 2; then compound 1.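

In this assay the ring of the leaving group turns out not to be required for a low number: with carboxy(difluoro)methyl, which has no ring and fewer heavy atoms than the group it replaces, the result is a 1.3-fold lower number from compound 3 to compound 4 (0.12 log units; within the scatter) and so no real change. Ring-free groups on this nitrogen also differ sharply from each other, as the replacement of 2-(methoxycarbonyl)ethyl gives a 6.7-fold lower number from compound 2 to compound 4 (0.82 log units; beyond the scatter) and thus shows that the group's identity matters beyond the presence or absence of a ring. Measured against the nitro starting point, the (carboxy(difluoro)methyl)amino group gives a 17-fold lower number from compound 1 to compound 4 (1.22 log units; beyond the scatter) and is a large step, so this position can shift the number considerably while two very different groups, in compound 3 and compound 4, land within the scatter of each other.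

Nothing available explains these differences. Still open, from the compounds shown here alone, is whether the fluorine atoms or the carboxylic acid account for the gap to compound 2, which a carboxymethyl group without fluorine, or the methyl ester of carboxy(difluoro)methyl, would help to separate.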